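Trimethoxyphenyl triazole thioethers: adding an aryl ketone

The compounds below may be only part of what the source reports. "The series", "measured", "known", "first", "only" and "open" are said of these compounds alone.

Working notes on the series. In a functional assay on HepG2 cells (Homo sapiens) for cytotoxicity, read by MTT assay, with a stated time of 48 h (a lower number here means a stronger inhibitor, a higher number a weaker inhibitor), compound 1 `CCc1nnc(SCc2ccccc2)n1N1C(=O)c2ccccc2C1=O` gives > 200000 nM, which is a limit of the assay and not a number. Compound 2 `COc1cc(-c2nnc(SCc3ccccc3Cl)n2N2C(=O)c3ccccc3C2=O)cc(OC)c1OC` likewise reaches only the limit > 200000 nM in this assay. Compound 3 `COc1cc(-c2nnc(SC)n2N2C(=O)c3ccccc3C2=O)cc(OC)c1OC` stands at the limit > 200000 nM in this assay as well. Two further values shown are also limits, so the place of compound 3 among the measured compounds cannot be ranked. Among the compounds with values here, the single measured step, a step that the two limits leave unreadable from compound 2 to compound 3, is unreadable in size: both of its ends are limits. The evidence amounts to the limit of > 200000 nM in this assay, at which 3 of the 3 values shown sit.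

Compound 4 `COc1cc(-c2nnc(SCC(=O)c3ccc(F)cc3)n2N2C(=O)c3ccccc3C2=O)cc(OC)c1OC` differs from compound 3 in one place: (4-fluorophenyl)carbonyl in place of hydrogen on a saturated chain carbon bound to a sulfur. Within the data shown here, no measured step bears readably on this change; the one step touching the same carbon, a step that the two limits leave unreadable from compound 2 to compound 3, gives no size. With every value in the series sitting at the limit, the step expected in this assay, a number no higher from compound 3 to compound 4 (the limit leaves the size open), is estimated to be of no readable size, and a reported limit rather than a number is the most probable outcome. The estimate for compound 4 in this assay is 200000 nM, with a range from 50000 nM to 400000 nM.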

Compound 4, half-maximal inhibitory concentration: > 200000 nM
Compound 4: no number, only a limit; the forecaster's own chance of this, stated with the estimate: 70%; the middle value sits exactly at the limit.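

Compound 4 also gives a limit and not a number, so neither the step to it from compound 3 nor the step from compound 2 can be read: the limit of > 200000 nM in this assay, at which 4 of the 4 values shown sit.

The compounds shown leave open whether any group on the saturated chain carbon bound to a sulfur changes the result in this assay: none of them gives a number.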